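Piperidine to Methylpiperazine Swap Carried Onto a Second Core

The source may hold more compounds than are shown below. What is called first, only, known or untested is meant among the compounds shown, and "the series" means these compounds.

Compound 1 `O=C(/C=C/CN1CCCCC1)Nc1cc2c(N3CCc4ccccc43)ncnc2cc1O[C@@H]1CCOC1`: in a functional assay on A549 cells (Homo sapiens) for antiproliferative activity, read by MTT assay, with a stated time of 72 h (a higher number here means a weaker inhibitor, a lower number a stronger inhibitor), compound 1 gives 4660 nM.
Compound 2 `CN1CCN(C/C=C/C(=O)Nc2cc3c(N4CCc5ccccc54)ncnc3cc2O[C@@H]2CCOC2)CC1`: compound 2 gives 6090 nM.
Compound 3 `COc1cc2ncnc(N3CCCc4ccccc43)c2cc1NC(=O)/C=C/CN1CCCCC1`: compound 3 gives 2880 nM.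

Compound 1 and compound 2 share one core and differ only by 4-methylpiperazin-1-yl in place of piperidin-1-yl on a saturated chain carbon bound to a double-bonded chain carbon. That step read a 1.3-fold higher number from compound 1 to compound 2 (0.12 log units; within the scatter), so the two values sit close together. Compound 3 rests on another core; the difference between the two cores is not broken down here. Its value lies close to that of compound 1 and apart from that of compound 2.

Compound 4 `COc1cc2ncnc(N3CCCc4ccccc43)c2cc1NC(=O)/C=C/CN1CCN(C)CC1` differs from compound 3 by 4-methylpiperazin-1-yl in place of piperidin-1-yl on a saturated chain carbon bound to a double-bonded chain carbon, the same change at the same place as before. Compound 4 is expected to move by a 1.3-fold higher number from compound 3 to compound 4 (0.11 log units; within the scatter), an expectation that rests on compound 1 and compound 2 showing a 1.3-fold higher number from compound 1 to compound 2 (0.12 log units; within the scatter). Compound 4 is therefore estimated at 3700 nM, within 1800 nM to 8000 nM.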

Compound 4, half-maximal inhibitory concentration: 7830 nM
Beside the measured number, compound 4's estimate is 2.1-fold (0.33 log units) below it; the measured number falls inside the stated range.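

On the core of compound 3, in this assay, putting 4-methylpiperazin-1-yl in place of piperidin-1-yl gave a 2.7-fold higher number from compound 3 to compound 4 (0.43 log units; beyond the scatter). Set beside the earlier step, the change reads no differently on the two cores: the same change on two cores in this assay, a 1.3-fold higher number (0.12 log units; within the scatter) from compound 1 to compound 2 and a 2.7-fold higher number (0.43 log units; beyond the scatter) from compound 3 to compound 4, 2.1-fold (0.32 log units) apart, within the scatter of two such steps. Among these compounds, only the step on the core of compound 3 lies beyond the scatter, and two pairs cannot show that the change has one fixed size throughout the series, nor that its size depends on the core.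

The compounds shown leave open how a morpholin-4-yl or a dimethylamino group would read on the same saturated chain carbon. They also leave open whether the two cores would keep reading alike with such amines.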